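From bromo to 5-methylthiophen-2-yl: working notes on cytotoxicity

A few compounds are considered here, and "the series" means these few. Any claim that something is new, unique, unknown or untested is made for them only; others in the source may bear on it.

Going by the values given here, in an ADME assay on HepG2 cells (Homo sapiens) for cytotoxicity, read by MTT assay, with a stated time of 24 h (on this read-out higher numbers stand for lower toxicity in this test and lower numbers for higher toxicity in this test), compound 1 `CC1Cn2c(nc([N+](=O)[O-])c2Br)O1` gives 20100 nM, the only actual number so far. Compound 2 `CC1Cn2c(nc([N+](=O)[O-])c2-c2ccc(Cl)cc2)O1` gives > 140000 nM, which is a limit and not a number. Among the compounds with values here, no step between two measured compounds is available, so any expectation rests on these two readings and the structural change.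

Compound 3 `Cc1ccc(-c2c([N+](=O)[O-])nc3n2CC(C)O3)s1` carries 5-methylthiophen-2-yl in place of bromo on an aromatic carbon of the core of compound 1 (5-methylthiophen-2-yl in place of bromo on an aromatic carbon). A rise in this assay, towards lower toxicity in this test, is expected from the reading of compound 2 at > 140000 nM, a limit. That reading gives no firm size for the step, and compound 3 may itself return only a limit. The expected change is sizeable and beyond the usual scatter, a 4.5-fold higher number from compound 1 to compound 3 (0.65 log units; beyond the scatter). For compound 3 the half-maximal cytotoxic concentration is estimated at 90000 nM, with an expected range of 35000 nM to 220000 nM.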

Compound 3, half-maximal cytotoxic concentration: > 250000 nM
Compound 3 gave a limit, no number; the forecaster's own chance of this, stated with the estimate: 50%; middle value at least 2.7-fold (0.44 log units) away from the limit.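

In this assay, going by these compounds alone, 5-methylthiophen-2-yl in place of bromo on this aromatic carbon, next to the ring atom that bears a nitro group, gives an at least 12-fold higher number from compound 1 to compound 3 (1.09 log units; beyond the scatter), the first step that can be read between two measured compounds and a large one towards lower toxicity in this test. The reading of compound 3 is a limit and not a number, so the step marks only how far the reading has moved at the least: the limit of > 250000 nM in this assay, at which 1 of the 3 values shown sits. Compound 2, with 4-chlorophenyl on the same carbon of the shared core, is also a limit, so the move away from the bromo reading now appears with two different aromatic groups rather than with one: the limit of > 140000 nM in this assay, at which 1 of the 3 values shown sits.

On these data alone, with no number for either compound, no order between compound 2 and compound 3 can be read, and the full size of the step from bromo remains unknown. Also open, as far as these compounds go, is whether a group without an aromatic ring on this carbon, such as an amine, a carboxylic acid or a short alkyl chain, would move the reading as far from that of compound 1.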